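Selenium Gives Way to Sulfur in Compound 4

A few compounds are considered here, and "the series" means these few. Any claim that something is new, unique, unknown or untested is made for them only; others in the source may bear on it.

Measured so far:
compound 1, `OCC#CCSc1cnc2ccccc2c1Cl`: 2.4 ug/mL
compound 2, `OCC#CCSc1cnc2ccccc2c1[Se]CC#CCBr`: 1.6 ug/mL
compound 3, `OCC#CCSc1cnc2ccccc2c1[Se]CC#CCO`: 4.1 ug/mL

These values come from a functional assay on P388 cells (Mus musculus) for cytotoxicity, read by MTT assay, with a stated time of 72 h; a higher number here means a weaker inhibitor, a lower number a stronger inhibitor. Compound 3 carries the highest of the three numbers; its step from compound 1 is within the scatter, a 1.7-fold higher number from compound 1 to compound 3 (0.23 log units; within the scatter), while the step from compound 2 lies beyond it, a 2.6-fold higher number from compound 2 to compound 3 (0.41 log units; beyond the scatter). Compound 4, `OCC#CCSc1cnc2ccccc2c1SCC#CCO`, differs from compound 3 by a group of 6 heavy atoms (4 carbon, 1 oxygen, 1 sulfur; no ring) in place of a group of 6 heavy atoms (4 carbon, 1 oxygen, 1 selenium; no ring), on an aromatic carbon. Among the measured compounds shown here, no measured step exchanges selenium for sulfur, so none bears directly on this change. The steps of a 1.5-fold lower number from compound 1 to compound 2 (0.18 log units; within the scatter) and a 1.7-fold higher number from compound 1 to compound 3 (0.23 log units; within the scatter), which replace chlorine with whole chains, stay within the scatter; only the bromo-to-hydroxy step a 2.6-fold higher number from compound 2 to compound 3 (0.41 log units; beyond the scatter) is modest and beyond it. Exchanging selenium for sulfur while keeping the chain is therefore expected to give no step beyond the scatter, a 1.0-fold lower number from compound 3 to compound 4 (0.01 log units; within the scatter). For compound 4 in this assay the estimate is 4 ug/mL, within 1.6 ug/mL to 10 ug/mL.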

Compound 4, concentration for 50% inhibition: 5.7 ug/mL
Estimate against measurement, compound 4: 1.4-fold (0.15 log units) below; the measured number falls inside the stated range.
By their numbers in this assay, from the lowest: compounds 2, 1, 3 and 4 (each within the scatter of the next, the first and the last beyond it).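

In this assay, exchanging selenium for sulfur on this aromatic carbon gives a 1.4-fold higher number from compound 3 to compound 4 (0.14 log units; within the scatter) and so separates the two atoms by no more than the scatter. Replacing chlorine with a chain now gives a step beyond the scatter, a 2.4-fold higher number from compound 1 to compound 4 (0.38 log units; beyond the scatter), and replacing the selenium chain ending in bromo with the sulfur chain ending in hydroxy gives a 3.6-fold higher number from compound 2 to compound 4 (0.55 log units; beyond the scatter) and stays modest. No measured evidence accounts for these steps.

On these data alone, whether a sulfur chain ending in bromo would match compound 2 remains open. So does the effect of an amine at the chain end, or of a longer chain.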